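The compounds below may be only part of what the source reports. "The series", "measured", "known", "first", "only" and "open" are said of these compounds alone.

Among the measured compounds shown here, compound 1 `CCCCCCCCc1cn([C@H]2C[C@@H]3OP(=O)(O)OC[C@H]3O2)c(=O)[nH]c1=O` is the only member of the pair that returns a number in a functional assay on Raji cells (Homo sapiens); on this read-out higher numbers stand for weaker inhibition and lower numbers for stronger inhibition: compound 1 gives 165 ug/mL. Compound 2 `CCCCc1cn([C@H]2C[C@H](O)[C@@H](CO)O2)c(=O)[nH]c1=O` stops at a limit of the assay in this assay, reported as > 500 ug/mL. That limit is described by the limit of > 500 ug/mL in this assay, at which 1 of the 2 values shown sits. Compound 3 `CCCCCc1cn([C@H]2C[C@@H]3OP(=O)(O)OC[C@H]3O2)c(=O)[nH]c1=O` has not yet been measured; it differs from compound 1 by hydrogen in place of propyl on a saturated chain carbon, five bonds along the chain from an aromatic carbon. For the measured compounds named here, compound 2 carries a butyl chain on a different sugar; no measured step links it to compound 3. The shorter chain is expected to weaken inhibition, with the step of a 2.1-fold higher number from compound 1 to compound 3 (0.33 log units; beyond the scatter) estimated to run beyond the scatter. Compound 3 is expected to come in near 350 ug/mL, within 130 ug/mL to 900 ug/mL.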

Compound 3, concentration for 50% inhibition: > 500 ug/mL
Compound 3 gave a limit, no number (the forecaster's own chance of this, stated with the estimate: 40%); middle value at least 1.4-fold (0.15 log units) away from the limit.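

In this assay, hydrogen in place of propyl on a saturated chain carbon, five bonds along the chain from an aromatic carbon, gives an at least 3.0-fold higher number from compound 1 to compound 3 (0.48 log units; beyond the scatter), so the outer part of the chain in compound 1 counts towards inhibition on this core. Compound 3 is a limit, not a number, so the step is open-ended: the limit of > 500 ug/mL in this assay, at which 2 of the 3 values shown sit.

As far as these compounds go, whether a chain longer than that of compound 1 would lower the number further stays open. So does whether a terminal amine or carboxylic acid on the chain would be tolerated.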